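Substitution on the dimethoxyphenyl group: compound 1 to compound 4

The source may report more compounds than this note shows. Statements on the series, on what has been measured and on what is new or still open speak of the compounds shown alone.

Measured compounds:
compound 1 `CCc1nn2c(-c3c(OC)cccc3OC)cccc2c1N(CC1CCOCC1)CC1CC1` — 105 nM
compound 2 `CCc1nn2c(-c3cc(OC)c(OC)cc3OC)cccc2c1N(CC1CCOCC1)CC1CC1` — 130 nM
compound 3 `CCc1nn2c(-c3c(C)cc(C)cc3OC)cccc2c1N(CC1CCOCC1)CC1CC1` — 22 nM

In an assay on HEK293 cells for displacement of a labelled ligand from corticotropin-releasing factor receptor 1 (Homo sapiens), read by scintillation counting, with a stated time of 2 h (a lower number here means a stronger inhibitor, a higher number a weaker inhibitor), compound 1 gives 105 nM, the second highest of the three numbers. Compound 2 gives 130 nM, and the two values lie within the scatter of each other, so no difference can be read between them. Compound 3 gives 22 nM; the step of a 4.8-fold lower number from compound 1 to compound 3 (0.68 log units; beyond the scatter) is the only one in the set that lies beyond the scatter, and it replaces 2,6-dimethoxyphenyl by 2-methoxy-4,6-dimethylphenyl rather than adding a group to an otherwise unchanged ring.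

Compound 4 `CCc1nn2c(-c3c(OC)cc(COC)cc3OC)cccc2c1N(CC1CCOCC1)CC1CC1` is not yet measured. It differs from compound 1 by methoxymethyl in place of hydrogen on an aromatic carbon with both methoxy groups kept. Among the measured compounds shown here, no measured step adds a group at that carbon while keeping the two methoxy groups; compound 2 shows an added methoxy elsewhere on the ring without a readable change, and the step to compound 3 changes several groups at once. A small step at most is therefore expected. For compound 4 in this assay a value of 90 nM is estimated, with a range of 40 nM to 220 nM. This estimate means a 1.2-fold lower number from compound 1 to compound 4 (0.07 log units; within the scatter) is expected.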

Compound 4, half-maximal inhibitory concentration: 50 nM
Compound 4: the middle estimate sits 1.8-fold (0.26 log units) above what was measured, and the stated range covers the measured number.
By their numbers in this assay, from the lowest: compound 3; then compound 4; then compounds 1 and 2 (each within the scatter of the next).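

In this assay, methoxymethyl in place of hydrogen on the aromatic carbon meta to two methoxy groups and para to a large group gives a 2.1-fold lower number from compound 1 to compound 4 (0.32 log units; beyond the scatter) and, unlike the added methoxy of compound 2, produces a readable change. Among the compounds shown here, this is the first single-place change to show that this carbon takes a substituent with both methoxy groups kept, and the number falls rather than rises. The step is modest, and one group at one carbon defines no trend. No measurement available here bears on the reason for this step.

On these data alone, whether the lower number depends on the ether oxygen or on the chain as such remains open, and a hydroxymethyl, an ethyl or a longer ether chain at this carbon would separate these. An aminomethyl or a carboxylic acid there is equally unresolved.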